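A few compounds are considered here, and "the series" means these few. Any claim that something is new, unique, unknown or untested is made for them only; others in the source may bear on it.

Compound 1 `C=CC(C)(C)c1[nH]c2ccc(C[C@@H](Cl)C(C)(C)O)cc2c1/C=C1\NC(=O)[C@H](C)NC1=O`: in a functional assay on A459 cells (Homo sapiens) for cytotoxicity, read by sulforhodamine B assay, with a stated time of 24 h (on this read-out lower numbers stand for stronger inhibition and higher numbers for weaker inhibition), compound 1 gives only a limit, > 50000 nM.
Compound 2 `C=CC(C)(C)c1[nH]c2ccc(C[C@@H](O)C(=C)C)cc2c1/C=C1\NC(=O)[C@H](C)NC1=O`: in this assay compound 2 gives only a limit, > 50000 nM.
Compound 3 `C=CC(C)(C)c1[nH]c2c(C[C@@H](O)C(C)(C)Cl)cccc2c1/C=C1\NC(=O)[C@H](C)NC1=O`: in this assay compound 3 gives only a limit, > 50000 nM.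

Within the data shown here, compound 3 stands at the assay ceiling, and it is not alone there: the limit of > 50000 nM in this assay, at which 3 of the 3 values shown sit, so no compound among the three shows a readable number. Among the measured compounds shown here, the single step between measured compounds that differ in one place, a step that the two limits leave unreadable from compound 1 to compound 2, is therefore unreadable as well, and it concerns a change on the saturated chain carbon of compound 1 rather than the change now in question.

Compound 4 `C=CC(C)(C)c1[nH]c2c(CC=C(C)C)cccc2c1/C=C1\NC(=O)[C@H](C)NC1=O` differs from compound 3 as follows: 2-methylprop-1-en-1-yl in place of 2-chloro-1-hydroxy-2-methylpropyl on a saturated chain carbon bound to an aromatic carbon. For the measured compounds named here, no measured step bears directly on this change, and nothing among the three values shows any compound leaving the limit. On that basis compound 4 is expected to remain at or near the limit as well, with the step that the limit leaves unreadable from compound 3 to compound 4 expected to be unreadable in practice. Compound 4 is estimated at 60000 nM, within a range of 20000 nM to 200000 nM, with a high chance that the assay again reports only a limit.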

Compound 4, half-maximal inhibitory concentration: > 50000 nM
Compound 4 ended at the assay's limit; the forecaster's own chance of this, stated with the estimate: 85%; the middle value does not contradict the limit.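

No step can be read from compound 3 to compound 4, as both give only a limit in this assay: the limit of > 50000 nM in this assay, at which 4 of the 4 values shown sit.

The compounds shown leave open whether any change to the shared core or its chains gives a readable value in this assay.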